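Phthalazinone series: chlorophenyl to benzyl at the chain carbon

The compounds below may be only part of what the source reports. "The series", "measured", "known", "first", "only" and "open" are said of these compounds alone.

Compound 2 `CN1CCC[C@@H]1Cn1nc(Cc2cccc(Cl)c2)c2ccccc2c1=O` gives 398 nM in an assay for binding affinity to Alpha-1A adrenergic receptor (Homo sapiens) (on this read-out higher numbers stand for weaker inhibition and lower numbers for stronger inhibition), the higher of the two numbers in hand. Compound 1 `O=c1c2ccccc2c(Cc2ccc(Cl)cc2)nn1C1CCCN(Cc2ccc(OCCCN3CCCCCC3)cc2)CC1` gives 100 nM in this assay. Compound 3 `CN1CCC[C@@H]1Cn1nc(Cc2ccc(C(C)(C)C)cc2)c2ccccc2c1=O` reaches only a limit of this assay, > 1990 nM; that limit is the limit of > 1990 nM in this assay, at which 1 of the 3 values shown sits. Compound 4 `CN1CCC[C@@H]1Cn1nc(CCc2ccccc2)c2ccccc2c1=O` is not yet measured. The change from compound 2 to compound 4 is benzyl in place of 3-chlorophenyl on a saturated chain carbon bound to an aromatic carbon. For the measured compounds named here, no measured pair shares this change, so the expected step rests on compound 2 alone; a rise in the number, with a moderate chance of a limit, is expected. The step from compound 2 to compound 4 is expected to be a 2.3-fold higher number from compound 2 to compound 4 (0.35 log units; beyond the scatter). For compound 4 the estimate in this assay is 900 nM, within 300 nM to 3000 nM.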

Compound 4, inhibition constant: 200 nM
Compound 4: middle estimate off by 4.5-fold (0.65 log units), on the high side; the measured number lies below the stated range.
By their numbers in this assay, from the lowest: compounds 1, 4 and 2 (each within the scatter of the next, the first and the last beyond it). At a limit, above all of these: compound 3.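

The step from 3-chlorobenzyl to phenethyl, read as benzyl in place of 3-chlorophenyl on a saturated chain carbon bound to an aromatic carbon, is a 2.0-fold lower number from compound 2 to compound 4 (0.30 log units; within the scatter). In this assay, this place therefore accepts phenethyl, and the chlorine is not needed to stay within the scatter of compound 2. Compound 3 remains the only compound at a limit: the limit of > 1990 nM in this assay, at which 1 of the 4 values shown sits.

As far as these compounds go, whether an amine, a carboxylic acid or a longer chain in place of phenethyl would hold the value of compound 4 at 200 nM stays open.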